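Inverting the ring stereocentre from compound 3 to compound 4

This account rests on a few compounds, and the source may have more. Where it says the series, first, only, none or still open, it means among the compounds named here.

Measured in an assay for inhibition of leukotriene B4 receptor (Homo sapiens); a lower number here means a stronger inhibitor, a higher number a weaker inhibitor:
compound 1 `CCCCCC(O)/C=C/[C@H]1CCC[C@@](O)(CC(=O)O)C1`: 8000 nM; > 10000 nM (2 entries).
compound 2 `O=C(O)/C=C1/CCC[C@H](/C=C/C(O)CCCCc2ccccc2)C1`: > 10000 nM; 500 nM; > 10000 nM (3 entries).
compound 3 `CN(C)OC(=O)/C=C1/CCC[C@H](/C=C/C(O)CCCCc2ccccc2)C1`: 7000 nM.

The entries of compound 1 with a greater-than sign in the several entries of compound 1 in this assay, 8000 nM; > 10000 nM (2 entries) are limits of the assay, not numbers. The entries of compound 2 with a greater-than sign in the several entries of compound 2 in this assay, > 10000 nM; 500 nM; > 10000 nM (3 entries) are likewise limits of the assay. Compound 3 thus stands on the only single number shown for it in this assay; two further entries for compound 3 gave no number at all, so its position is loosely fixed.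

Compound 4 `CN(C)OC(=O)/C=C1/CCC[C@@H](/C=C/C(O)CCCCc2ccccc2)C1` differs from compound 3 only in configuration: the two compounds have the same atoms and bonds; at least one stereo element is drawn with a configuration in one of them and without one in the other: 1 of 4 stereo elements differ; a stereocentre at a saturated ring carbon is drawn S in compound 3 and R in compound 4. Among the compounds with values here, no step between measured compounds bears on such an inversion, so no size can be taken from the data. The expected step from compound 3 to compound 4 in this assay is a 1.1-fold higher number from compound 3 to compound 4 (0.06 log units; within the scatter), which is within the scatter. Compound 4 is estimated at 8000 nM, with a range from 1500 nM to 30000 nM, and a limit-only report is quite possible.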

Compound 4, half-maximal inhibitory concentration: 1000 nM
Compound 4: middle estimate off by 8.0-fold (0.90 log units), on the high side; measured number outside the range, below it.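

In this assay, within the data shown here, the configuration at this saturated ring carbon is the first structural change with a readable size: a 7.0-fold lower number from compound 3 to compound 4 (0.85 log units; beyond the scatter). Atoms and bonds are the same in the two compounds, so the step belongs to this one stereocentre, and the R drawing gives the lower number of the pair. The reading carries a caveat in how the pair is drawn: the fact that one of compounds 3 and 4 is drawn with a defined configuration and the other without, at the place where they differ

The compounds shown leave open whether the same preference holds with a methyl ester or a primary amide in place of the present ester group. Compound 3 and compound 4 also carry no drawn configuration at the hydroxyl-bearing chain carbon, so any contribution from that centre cannot be read.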